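From phenyl to 1-methyl-1H-indol-5-yl on the shared core

A few compounds are considered here, and "the series" means these few. Any claim that something is new, unique, unknown or untested is made for them only; others in the source may bear on it.

In a functional assay on MGC-803 cells (Homo sapiens) for inhibition, read by MTT assay, with a stated time of 48 h (on this read-out higher numbers stand for weaker inhibition and lower numbers for stronger inhibition), compound 2 `COc1cc(Nc2nc(Nc3ccccc3)nnc2Cl)cc(OC)c1OC` gives 8750 nM. Compound 1 `COc1cc(Nc2nc(Nc3ccc(Cl)cc3)nnc2Cl)cc(OC)c1OC` gives 12600 nM, and these two values lie within the usual scatter of each other, so neither can be ranked ahead. Compound 3 `COc1cc(Nc2nc(Nc3ccc4c(ccn4C)c3)nnc2Cl)cc(OC)c1OC` keeps the shared core but carries 1-methyl-1H-indol-5-yl in place of phenyl on a nitrogen on an aromatic ring. Within the data shown here, only one measured step bears on this change: a 1.4-fold lower number from compound 1 to compound 2 (0.16 log units; within the scatter), with hydrogen in place of chloro on an aromatic carbon. That step stays within the scatter and involves a much smaller change, so it says little about swapping the whole group. A modest move towards stronger inhibition in this assay is expected, held loosely, and the estimated step is a 2.5-fold lower number from compound 2 to compound 3 (0.40 log units; beyond the scatter). For compound 3 the estimated value is 3500 nM, with an expected range from 600 nM to 15000 nM.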

Compound 3, half-maximal inhibitory concentration: 28100 nM
Compound 3: middle estimate off by 8.0-fold (0.90 log units), on the low side, outside the stated range (above it).
By their numbers in this assay, from the lowest: compounds 2 and 1 (each within the scatter of the next); then compound 3.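

In this assay, putting 1-methyl-1H-indol-5-yl in place of phenyl on this nitrogen gives a 3.2-fold higher number from compound 2 to compound 3 (0.51 log units; beyond the scatter), and putting it in place of 4-chlorophenyl gives a 2.2-fold higher number from compound 1 to compound 3 (0.35 log units; beyond the scatter). Both steps lie beyond the scatter and point towards weaker inhibition, so this position does respond when the whole group changes, whereas swapping chloro for hydrogen on the phenyl ring gave no readable difference. Nothing available explains why the number rises with this group.

The compounds shown cannot separate a contribution from the methyl on the indole nitrogen from a contribution of the two-ring group as a whole. On these data alone, how this assay would respond to a phenyl ring carrying an amine or a carboxylic acid, or to a short alkyl chain on this nitrogen, also remains open.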